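The compounds below may be only part of what the source reports. "The series", "measured", "known", "first", "only" and "open" are said of these compounds alone.

Compound 1 `COc1cccc(NC(=O)COc2ccc3cc(/C=C4/SC(=O)NC4=O)ccc3c2)c1` is tested in an assay on isolated protein for inhibition of histone deacetylase 8 (Homo sapiens), with a stated time of 1 h (a higher number here means a weaker inhibitor, a lower number a stronger inhibitor), where compound 1 gives 7600 nM. That is the higher of the two plain numbers available, yet compound 2 `O=C(COc1ccc2cc(/C=C3/SC(=O)NC3=O)ccc2c1)Nc1ccccc1` gives 4500 nM, and the step of a 1.7-fold lower number from compound 1 to compound 2 (0.23 log units; within the scatter) stays within the scatter. Compound 3 `O=C(COc1ccc2cc(/C=C3/SC(=O)NC3=O)ccc2c1)Nc1cccc(C(F)(F)F)c1` reaches only a limit of the assay, > 50000 nM. The change from compound 1 to compound 4 `COc1ccc(NC(=O)COc2ccc3cc(/C=C4/SC(=O)NC4=O)ccc3c2)cc1` is 4-methoxyphenyl in place of 3-methoxyphenyl on an amide-type nitrogen. Within the data shown here, no measured step moves a methoxy from one place on the ring to another; the steps of an at least 6.5-fold higher number from compound 1 to compound 3 (0.81 log units; beyond the scatter) and an at least 11-fold higher number from compound 2 to compound 3 (1.04 log units; beyond the scatter) concern trifluoromethyl and rest on the limit (the limit of > 50000 nM in this assay, at which 1 of the 3 values shown sits). So no step beyond the scatter is expected in this assay. Compound 4 is expected to give 7000 nM, between 2500 nM and 25000 nM, a step of a 1.1-fold lower number from compound 1 to compound 4 (0.04 log units; within the scatter).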

Compound 4, half-maximal inhibitory concentration: > 50000 nM
Compound 4: no number, only a limit (the forecaster's own chance of this, stated with the estimate: 10%); at least 7.1-fold (0.85 log units) between middle value and limit.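

Moving the methoxy around the same ring now matters in this assay: replacing 3-methoxyphenyl with 4-methoxyphenyl gives an at least 6.5-fold higher number from compound 1 to compound 4 (0.81 log units; beyond the scatter), and adding this methoxy to the unsubstituted ring gives an at least 11-fold higher number from compound 2 to compound 4 (1.04 log units; beyond the scatter). So among these compounds, where the methoxy sits counts, not only whether one is present. The step between compound 3 and compound 4 cannot be read, and both sizes above rest on a limit: the limit of > 50000 nM in this assay, at which 2 of the 4 values shown sit.

Still open, on these data alone, is how far compound 4 lies past that limit. Also open, as far as these compounds go, is whether an amine or a carboxylic acid in place of its methoxy would give a readable number.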